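The compounds below may be only part of what the source reports. "The series", "measured", "known", "first", "only" and "open" are said of these compounds alone.

In a functional assay on HL-60 cells (Homo sapiens) for inhibition, read by MTT assay, with a stated time of 48 h, tested at 10 uM (a lower number here means less inhibition of growth, a higher number more inhibition of growth at the concentration tested), compound 1 `Cc1oc2c([C@H]3CCN(C)C[C@H]3O)c(O)cc(O)c2c(=O)c1C(O)c1cccc(Cl)c1` gives 22% and compound 2 `Cc1oc2c([C@H]3CCN(C)C[C@H]3O)c(O)cc(O)c2c(=O)c1C(O)c1cccc(Cl)c1Cl` gives 12%. The difference between the two is chloro in place of hydrogen on an aromatic carbon and the step is a number 10 percentage points lower from compound 1 to compound 2 (within the scatter). Compound 3 `CN1CC[C@H](c2c(O)cc(O)c3c(=O)cc(/C=C/c4ccccc4)oc23)[C@H](O)C1` gives 91%, the highest of the three measured values. How the core of compound 3 differs from the core of compound 1 is not broken down here. Compound 4 `CN1CC[C@H](c2c(O)cc(O)c3c(=O)cc(/C=C/c4ccc(Cl)cc4)oc23)[C@H](O)C1` differs from compound 3 by chloro in place of hydrogen on an aromatic carbon. This is the same kind of change as that from compound 1 to compound 2, but the place is not identical: in the earlier pair the chloro enters ortho to a chloro group and ortho to a large group, whereas in compound 4 it enters para to a large group. Because a number 10 percentage points lower from compound 1 to compound 2 (within the scatter) lay within the scatter, an estimated step of a number 5 percentage points lower from compound 3 to compound 4 (within the scatter) is expected. The expected value of compound 4 is 86%, estimated to fall between 70% and 96%.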

Compound 4, percent growth inhibition at one concentration: 58%
Compound 4: middle estimate off by 28 percentage points, on the high side, and the stated range ends above it.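

In this assay, chloro in place of hydrogen on an aromatic carbon gives a number 33 percentage points lower from compound 3 to compound 4 (beyond the scatter). Set beside the earlier pair, the same change does not carry over at one size from one core to the other: the same change on two cores in this assay, a number 10 percentage points lower (within the scatter) from compound 1 to compound 2 and a number 33 percentage points lower (beyond the scatter) from compound 3 to compound 4, 23 percentage points apart, beyond the scatter of two such steps This rests on only two pairs, and the chloro enters at a different place in each, so the result does not separate the role of the core from that of the place.

As far as these compounds go, it remains open whether an amine or a methoxy group at the same place would leave compound 3 near its 91%. Also open, from the compounds shown here alone, is how a longer chain in place of the 2-phenylethenyl group would read in this assay.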